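Trimethoxyphenyl amides: methoxy to methyl on the acyl chain

The source may hold more compounds than are shown below. What is called first, only, known or untested is meant among the compounds shown, and "the series" means these compounds.

Compound 1 `COCC(=O)N(Cc1ccc(OC)c(O)c1)c1cc(OC)c(OC)c(OC)c1`: 460 nM
Compound 2 `C/C=C/C(=O)N(Cc1ccc(OC)c(N)c1)c1cc(OC)c(OC)c(OC)c1`: 310 nM
Compound 3 `COc1ccc(CNc2cc(OC)c(OC)c(OC)c2)cc1F`: 46200 nM

In a functional assay on KYSE-450 cells (Homo sapiens) for inhibition, read by MTT assay, with a stated time of 48 h (a higher number here means a weaker inhibitor, a lower number a stronger inhibitor), compound 1 gives 460 nM, the second highest of the three numbers. Compound 2 gives 310 nM, which lies within the scatter of compound 1. Compound 3 gives 46200 nM, a far higher number than compound 1, beyond the scatter.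

Compound 4 `CCC(=O)N(Cc1ccc(OC)c(O)c1)c1cc(OC)c(OC)c(OC)c1` is not yet measured. It differs from compound 1 by methyl in place of methoxy on a saturated chain carbon bound to a carbonyl carbon. Among the measured compounds shown here, no measured pair shows this change, so its effect is unknown. Since the acyl chain is a small part of the shared core, a step within the scatter is expected in either direction.

Compound 4 is therefore expected to give 400 nM, with a likely range from 150 nM to 1200 nM, corresponding to an estimated step of a 1.2-fold lower number from compound 1 to compound 4 (0.06 log units; within the scatter).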

Compound 4, half-maximal inhibitory concentration: 98 nM
For compound 4 the middle estimate is 4.1-fold (0.61 log units) above the measured one; the measured number lies below the stated range.
By their numbers in this assay, from the lowest: compound 4; then compounds 2 and 1 (each within the scatter of the next); then compound 3.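

In this assay, methyl in place of methoxy on a saturated chain carbon bound to a carbonyl carbon gives a 4.7-fold lower number from compound 1 to compound 4 (0.67 log units; beyond the scatter), so this acyl chain position responds to a small change. This is the only pair shown that differs in one place, and here propanoyl gives the stronger inhibitor than (methoxymethyl)carbonyl on the shared core. Nothing given here accounts for the step.

As far as these compounds go, whether a longer chain, a hydroxyl or an amine at this chain carbon would give a lower or higher number stays open. So does whether the same change would give a similar step on other cores.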